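The source may hold more compounds than are shown below. What is called first, only, known or untested is meant among the compounds shown, and "the series" means these compounds.

Working notes on the series. Among the compounds with values here, in a functional assay on B16 cells (Mus musculus) for cytotoxicity, read by MTT assay, with a stated time of 48 h (a higher number here means a weaker inhibitor, a lower number a stronger inhibitor), compound 2 `CC1(C)OC[C@H](Cn2cc(-c3ccc4ccccc4c3)nn2)O1` gives 12000 nM, the only number among the three values shown. Compound 3 `Cc1ccc(C(O)c2cn(C[C@H]3COC(C)(C)O3)nn2)cc1` returns only a limit of the assay, > 100000 nM. Compound 1 `Cc1ccc(C(O)c2cn(Cc3ccccc3)nn2)cc1` likewise returns a limit, > 100000 nM. The change from compound 3 to compound 1, (phenyl in place of 2,2-dimethyl-1,3-dioxolan-4-yl on a saturated chain carbon bound to an aromatic nitrogen), is thus a step that the two limits leave unreadable from compound 3 to compound 1, with both ends sitting at the limit of > 100000 nM in this assay, at which 2 of the 3 values shown sit. How the core of compound 2 differs from that of compound 3 is not broken down here. Compound 4 `c1ccc(Cn2cc(-c3ccc4ccccc4c3)nn2)cc1`, not yet measured, carries the same change from compound 2: phenyl in place of 2,2-dimethyl-1,3-dioxolan-4-yl on a saturated chain carbon bound to an aromatic nitrogen. The measured instance of this change being unreadable, the expectation rests on compound 2 at 12000 nM, and the step from compound 2 to compound 4 is estimated as a 1.3-fold higher number from compound 2 to compound 4 (0.10 log units; within the scatter). Compound 4 is expected near 15000 nM, between 4000 nM and 100000 nM.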

Compound 4, half-maximal inhibitory concentration: 3890 nM
Beside the measured number, compound 4's estimate is 3.9-fold (0.59 log units) above it; measured number below the stated range.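

On the core of compound 2, in this assay, phenyl in place of 2,2-dimethyl-1,3-dioxolan-4-yl gives a 3.1-fold lower number from compound 2 to compound 4 (0.49 log units; beyond the scatter). On the core of compound 3 the same change cannot be read, since compound 3 and compound 1 each return only a limit of the assay: the limit of > 100000 nM in this assay, at which 2 of the 4 values shown sit.

This leaves one readable instance of the change, so it shows a lower number on one core but does not show that the step carries over to another core. The compounds shown leave open whether the step recurs on any further core. They also leave open how an amine or a carboxylic acid would compare with phenyl on a saturated chain carbon bound to an aromatic nitrogen.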